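Swapping One Ring Substituent on a Sulfonamide Orexin Blocker

The source may hold more compounds than are shown below. What is called first, only, known or untested is meant among the compounds shown, and "the series" means these compounds.

compound 1 `CCN(CC)C(=O)CN(c1ccc(C)cc1)S(=O)(=O)c1cccc(Cl)c1`: 139 nM
compound 2 `CCN(CC)C(=O)CN(c1ccc(C)cc1)S(=O)(=O)c1cccc(C)c1`: 60 nM

Both compounds were tested in a functional assay on CHO cells for inhibition of Orexin receptor type 2 (Homo sapiens), read by FLIPR and calcium flux; a lower number here means a stronger inhibitor, a higher number a weaker inhibitor. Among the measured compounds shown here, compound 2 gives the lower of the two numbers, with compound 1 as its only neighbour; that gap is a 2.3-fold lower number from compound 1 to compound 2 (0.36 log units; beyond the scatter). Compound 3 `CCN(CC)C(=O)CN(c1ccc(C)cc1)S(=O)(=O)c1cccc(F)c1` differs from compound 2 by one change, (fluoro in place of methyl on an aromatic carbon), at a carbon of the six-membered aromatic ring of carbon only, meta to a large group. For the measured compounds named here, the single measured step at this place, a 2.3-fold lower number from compound 1 to compound 2 (0.36 log units; beyond the scatter), involved chloro, not fluoro, so the direction is uncertain. Compound 3 is expected at 100 nM, within 40 nM to 250 nM. The expected step is a 1.7-fold higher number from compound 2 to compound 3 (0.22 log units; within the scatter) in this assay.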

Compound 3, half-maximal inhibitory concentration: 839 nM
For compound 3 the middle estimate is 8.4-fold (0.92 log units) below the measured one, outside the stated range (above it).
By their numbers in this assay, from the lowest: compound 2; then compound 1; then compound 3.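

In this assay this ring position proves far more sensitive than the first pair suggested: fluoro in place of methyl gives a 14-fold higher number from compound 2 to compound 3 (1.15 log units; beyond the scatter), and fluoro in place of chloro gives a 6.0-fold higher number from compound 1 to compound 3 (0.78 log units; beyond the scatter). Compound 3 is thus the weakest of the three, although each swap trades one heavy atom for one heavy atom and adds no hydrogen-bond donor or acceptor. Nothing measured here accounts for this gap. The compounds shown leave open how a methoxy group, an ethyl group or an amine would fare at this carbon, and whether fluoro costs as much elsewhere on this ring.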